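This account rests on a few compounds, and the source may have more. Where it says the series, first, only, none or still open, it means among the compounds named here.

Measured compounds in a functional assay on T47D cells (Homo sapiens) for cytotoxicity, read by sulforhodamine B assay, with a stated time of 24 h; on this read-out lower numbers stand for stronger inhibition of growth and higher numbers for weaker inhibition of growth:
compound 1 `COc1ccc(C(=O)/C=C/c2cc3ccccc3[nH]c2=O)cc1`, giving 3550 nM;
compound 2 `O=C(/C=C/c1cc2ccccc2[nH]c1=O)c1ccc(O)cc1`, giving 4190 nM.

Compound 2 holds the highest of the two numbers, with compound 1 nearest; the step of a 1.2-fold higher number from compound 1 to compound 2 (0.07 log units; within the scatter) lies within the scatter. Compound 3 `O=C(/C=C/c1cc2ccccc2[nH]c1=O)c1ccc(Cl)cc1` differs from compound 2 by chloro in place of hydroxy on an aromatic carbon. For the measured compounds named here, the only measured step touches the same aromatic carbon through its oxygen, and it showed no movement, so no step beyond the scatter is expected for compound 3 in this assay. For compound 3 the expected value is 3500 nM, within 1200 nM to 10000 nM, an expected step of a 1.2-fold lower number from compound 2 to compound 3 (0.08 log units; within the scatter).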

Compound 3, concentration for 50% growth inhibition: 7310 nM
For compound 3 the middle estimate is 2.1-fold (0.32 log units) below the measured one; measured number inside the range.
By their numbers in this assay, from the lowest: compounds 1, 2 and 3 (each within the scatter of the next, the first and the last beyond it).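

In this assay, exchanging hydroxy for chloro on this aromatic carbon, para to a large group, stays within the scatter, with a 1.7-fold higher number from compound 2 to compound 3 (0.24 log units; within the scatter) as the step. For the compounds shown here, exchanging methoxy for chloro at the same carbon gives the first step at this position beyond the scatter, though a modest one, with a 2.1-fold higher number from compound 1 to compound 3 (0.31 log units; beyond the scatter) as its size, so the position is not entirely indifferent to its substituent. Nothing available gives a reason for this difference. The compounds shown leave open how an amine, a carboxylic acid or a longer alkoxy chain at this carbon would read in this assay.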